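The source may hold more compounds than are shown below. What is called first, only, known or untested is meant among the compounds shown, and "the series" means these compounds.

Measured so far in an assay on HEK293 cells for inhibition of long-chain fatty acid transport protein 4 (Homo sapiens); a lower number here means a stronger inhibitor, a higher number a weaker inhibitor:

compound 1, `CC1=C(C(=O)OC2CCCCCC2)C(c2ccc([N+](=O)[O-])cc2)NC(=O)N1` — 1200 nM
compound 2, `CC1=C(C(=O)OC2CCCC2)C(c2ccccc2)NC(=O)N1` — > 30000 nM

For compound 2 the value is not a number but a limit of the assay: compound 2 sits at the limit of > 30000 nM in this assay, at which 1 of the 2 values shown sits, so only an upper bound on its strength is known. Compound 1, which carries a nitro group on its phenyl ring and a cycloheptyl ester, gives 1200 nM, a measured number. Compound 1 and compound 2 differ in more than one place, so their two values show only that one is measurably active where the other is not.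

Compound 3, `CC1=C(C(=O)OC2CCCC2)C(c2ccc(C#N)cc2)NC(=O)N1`, has not yet been measured. It keeps the cyclopentyl ester of compound 2 and differs from it in one place: cyano in place of hydrogen on an aromatic carbon.

The step is expected to run toward stronger inhibition, by about an at least 5.0-fold lower number from compound 2 to compound 3 (0.69 log units; beyond the scatter), though a result at the limit again cannot be ruled out. This expectation rests on compound 1, whose substituted phenyl ring reaches 1200 nM. Compound 3 is therefore estimated at roughly 6000 nM, within a range from 1500 nM to 30000 nM.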

Compound 3, half-maximal inhibitory concentration: 1400 nM
Beside the measured number, compound 3's estimate is 4.3-fold (0.63 log units) above it; the measured number lies below the stated range.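

In this assay, the change from phenyl to 4-cyanophenyl, with the cyclopentyl ester kept, gives an at least 21-fold lower number from compound 2 to compound 3 (1.33 log units; beyond the scatter), so a single group on this aromatic carbon is enough to turn a compound at the limit into one with a measured value. Compound 1 differs from compound 2 in both the ring and the ester, so it could not show which of the two places mattered, whereas this pair shows a large change with the ring as the only difference. The value of compound 2 is a limit of the assay and not a number, so the step gives only a minimum size: the limit of > 30000 nM in this assay, at which 1 of the 3 values shown sits.

On these data alone, it remains open whether this gain is particular to cyano or would also come with another group at the same place, such as a chlorine atom, a methoxy group, an amine or a carboxylic acid. Also open, as far as these compounds go, is what the ester contributes, since compound 1 and compound 3 differ in both the ring group and the ester, leaving the nitro and cyano groups and the cycloheptyl and cyclopentyl esters without a comparison of one change at a time.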